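Cytotoxicity Limits and an Aryl Ester in Place of Cyclopropyl

The compounds below may be only part of what the source reports. "The series", "measured", "known", "first", "only" and "open" are said of these compounds alone.

Three compounds on the shared core differ in the group on an oxygen on an aromatic ring: compound 1 `C#CCOc1cc(/C=C/C(=O)c2ccc(OC)c3c2OC(C)(C)C=C3)ccc1OC` with propargyl, compound 2 `C=CCOc1cc(/C=C/C(=O)c2ccc(OC)c3c2OC(C)(C)C=C3)ccc1OC` with allyl and compound 3 `COc1ccc(/C=C/C(=O)c2ccc(OC)c3c2OC(C)(C)C=C3)cc1OC(=O)C1CC1` with cyclopropylcarbonyl. In an ADME assay on L02 cells (Homo sapiens) for cytotoxicity, read by MTT assay (on this read-out higher numbers stand for weaker inhibition and lower numbers for stronger inhibition), compound 1 gives > 10000 nM, which is a limit and not a number. Compound 2 gives > 20000 nM, also a limit. Compound 3 gives > 10000 nM, likewise a limit, so it stands with the other two compounds at the limits of this assay.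

Compound 4 `COc1cccc(C(=O)Oc2cc(/C=C/C(=O)c3ccc(OC)c4c3OC(C)(C)C=C4)ccc2OC)c1` has 3-methoxyphenyl in place of cyclopropyl on a carbonyl carbon. The measured steps nearest to this change are a step that the two limits leave unreadable from compound 1 to compound 3 and a step that the two limits leave unreadable from compound 2 to compound 3, and alongside them stands a step that the two limits leave unreadable from compound 1 to compound 2. None of the three has a readable size, and none alters the group on the carbonyl carbon. They therefore support no expected direction, and no step beyond the scatter can be forecast from them. The expected change is a step that the limit leaves unreadable from compound 3 to compound 4. A further limit is the most likely report. Should a number be obtained, the estimate for compound 4 is 15000 nM, with an expected range from 7000 nM to 40000 nM.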

Compound 4, half-maximal inhibitory concentration: > 10000 nM
Compound 4 was reported as a limit (the forecaster's own chance of this, stated with the estimate: 80%); the middle value lies beyond the limit too.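

In this assay compound 4 gives > 10000 nM, which is again a limit and not a number, so its steps from compound 1, compound 2 and compound 3 cannot be read. The compounds shown leave open whether exchanging any of these groups changes the read-out at all: the limit of > 10000 nM in this assay, at which 3 of the 4 values shown sit.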